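The compounds below may be only part of what the source reports. "The series", "measured", "known", "first", "only" and "open" are said of these compounds alone.

Measured so far in a functional assay on NCI-H460 cells (Homo sapiens) for antiproliferative activity, read by CCK-8 assay, with a stated time of 72 h, tested at 8 uM; a higher number here means a stronger effect of the compound at the concentration tested, a lower number a weaker effect:
compound 1, `Nc1ccccc1NC(=O)c1ccc(Cn2cnc3c(Nc4ccccc4)nc(Cl)nc32)cc1`: 77.8%
compound 2, `CCCCn1cnc2c(Nc3ccccc3)nc(NCOCc3ccc(C(=O)Nc4ccccc4N)cc3)nc21`: 51.3%
compound 3, `Nc1ccccc1NC(=O)c1ccc(Cn2cnc3c(Nc4cccc(Cl)c4)nc(Cl)nc32)cc1`: 67%

Compound 1 and compound 3 share a core; compound 3 carries the change (chloro in place of hydrogen on an aromatic carbon). The step of a number 10.8 percentage points lower from compound 1 to compound 3 (beyond the scatter) goes with that change. Compound 2 has a different core; the difference between the two cores is not broken down here. In this assay compound 2 gives 51.3%, the lowest of the three numbers, and its gap to compound 3 as well as to compound 1 lies beyond the scatter.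

Compound 4, `CCCCn1cnc2c(Nc3cccc(Cl)c3)nc(NCOCc3ccc(C(=O)Nc4ccccc4N)cc3)nc21`, is not yet measured. It stands to compound 2 as compound 3 stands to compound 1: the change chloro in place of hydrogen on an aromatic carbon is the same change at the same kind of place, on the other core. Going by the values given here, the only precedent is the modest downward step from compound 1 to compound 3. Among the compounds with values here, on that precedent a step of similar size is expected, a number 9.3 percentage points lower from compound 2 to compound 4 (within the scatter), with wide bounds because the core is different and only one pair shows the change. For compound 4 the estimate in this assay is 42%, between 28% and 55%.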

Compound 4, a percentage reported as inhibition, at one concentration (the size of the read-out at that concentration, not a potency): 62%
The estimate for compound 4 lay 20 percentage points below the measured number, outside the stated range (above it).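

In this assay, chloro in place of hydrogen on an aromatic carbon goes with a number 10.7 percentage points higher from compound 2 to compound 4 (beyond the scatter), so on these two cores the change does not carry over with the same sign: the same change on two cores in this assay, a number 10.8 percentage points lower (beyond the scatter) from compound 1 to compound 3 and a number 10.7 percentage points higher (beyond the scatter) from compound 2 to compound 4, 21.5 percentage points apart, beyond the scatter of two such steps. This shows that a step read on the core of compound 1 is no safe guide to the same change on the core of compound 2, even though the two steps are both modest in size. Going by these compounds alone, it does not show which part of the difference between the cores goes with the reversal, since the cores differ in more than one place and each offers only a single pair, read at a single concentration and not as a potency.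

Open, going by these compounds, is whether other groups at the same place, such as fluoro, methoxy or a carboxylic acid, split between the two cores in the same way. Also open, on these data alone, is whether a longer chain in place of the butyl group of compound 4 would keep the upward step.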